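This account rests on a few compounds, and the source may have more. Where it says the series, first, only, none or still open, it means among the compounds named here.

Compounds measured so far:

compound 1, `CCCN1CC(=O)N(Cc2ccc(C(=O)NO)cc2)C1=O`, 53.4 nM
compound 2, `CC(C)CC1C(=O)N(Cc2ccc(C(=O)NO)cc2)C(=O)N1C`, 251 nM

Both compounds were tested in an assay on isolated protein for inhibition of protein deacetylase HDAC6 (Homo sapiens), read by fluorescence, with stated times of 10 min and 2 h; on this read-out higher numbers stand for weaker inhibition and lower numbers for stronger inhibition. Compound 1, with structure `CCCN1CC(=O)N(Cc2ccc(C(=O)NO)cc2)C1=O`, gives 53.4 nM. Compound 2, with structure `CC(C)CC1C(=O)N(Cc2ccc(C(=O)NO)cc2)C(=O)N1C`, gives 251 nM, which is the higher of the two numbers and lies beyond the usual scatter from the value of compound 1, so compound 2 is the weaker inhibitor of the pair on this read-out. Among the compounds with values here, the two compounds differ in more than one place, so no single step is drawn between them.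

Compound 3, `CCCN1C(=O)N(Cc2ccc(C(=O)NO)cc2)C(=O)C1CC(C)C`, is the next compound. It is obtained from compound 2 by the change (ethyl in place of hydrogen on a saturated chain carbon bound to an amide-type nitrogen in a ring). Compound 3 thus carries the propyl group on the ring nitrogen that compound 1 already bears, while keeping the isobutyl substituent of compound 2. No measured step of exactly this kind exists among the two compounds shown. Since compound 1, which carries the propyl on the ring nitrogen, gives 53.4 nM, a move toward a lower number is expected for compound 3, by the step of a 1.8-fold lower number from compound 2 to compound 3 (0.25 log units; within the scatter) in this assay. Compound 3 is therefore estimated at 140 nM, with a range from 50 nM to 400 nM.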

Compound 3, half-maximal inhibitory concentration: 174 nM
Beside the measured number, compound 3's estimate is 1.2-fold (0.09 log units) below it; the range from low to high includes it.
By their numbers in this assay, from the lowest: compound 1; then compounds 3 and 2 (each within the scatter of the next).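

In this assay, ethyl in place of hydrogen on a saturated chain carbon bound to an amide-type nitrogen in a ring, which reads as methyl to propyl, gives a 1.4-fold lower number from compound 2 to compound 3 (0.16 log units; within the scatter) with the isobutyl group kept in place. With the propyl group held constant, isobutyl in place of hydrogen on a saturated ring carbon gives a 3.3-fold higher number from compound 1 to compound 3 (0.51 log units; beyond the scatter) as a modest step. Within the data shown here, of the two places in which compound 1 and compound 2 differ, only this ring carbon therefore shows a step beyond the scatter.

As far as these compounds go, whether a longer chain than propyl or a chain ending in an amine would behave alike stays open, as does whether methyl or benzyl on the ring carbon would follow isobutyl. Nothing shown gives a reason for either step.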